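A few compounds are considered here, and "the series" means these few. Any claim that something is new, unique, unknown or untested is made for them only; others in the source may bear on it.

Of the compounds shown here, three built on a shared core have so far been tested in a functional assay, tested at 50 ug/mL; on this read-out lower numbers stand for a weaker effect and higher numbers for a stronger effect at the one concentration tested. Compound 1 `Cc1ccccc1C1C(C#N)=C(N)OC(c2c[nH]c3ccccc23)=C1C#N` gives 10.4% in this assay. Compound 2 `Cc1ccc(C2C(C#N)=C(N)OC(c3c[nH]c4ccccc34)=C2C#N)cc1` gives 5.2% in this assay. Compound 3 `COc1ccc(C2C(C#N)=C(N)OC(c3c[nH]c4ccccc34)=C2C#N)cc1` gives 12.4% in this assay. Compound 3 holds the highest of the three numbers, yet both of its neighbours sit within the usual scatter of it: a number 2 percentage points higher from compound 1 to compound 3 (within the scatter) and a number 7.2 percentage points higher from compound 2 to compound 3 (within the scatter). The remaining pair behaves the same way, a number 5.2 percentage points lower from compound 1 to compound 2 (within the scatter).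

Compound 4 `N#CC1=C(N)OC(c2c[nH]c3ccccc23)=C(C#N)C1c1ccc(F)cc1` has not yet been measured in this assay. It differs from compound 3 in a single place: fluoro in place of methoxy on an aromatic carbon. The measured step that bears most directly on this exchange is the swap of one group for another at the same aromatic carbon, a number 7.2 percentage points higher from compound 2 to compound 3 (within the scatter), and the swap of the whole aryl group, a number 2 percentage points higher from compound 1 to compound 3 (within the scatter), also stayed within the scatter. Within the data shown here, since no step among the three measured compounds went beyond the scatter, a step within the scatter, in no firm direction, is expected for compound 4 as well: a number 3.4 percentage points lower from compound 3 to compound 4 (within the scatter). The estimate for compound 4 in this assay is therefore 9%, with a range from 2% to 18%.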

Compound 4, a percentage reported as activity, at one concentration (the size of the read-out at that concentration, not a potency): 8.4%
Estimate against measurement, compound 4: 0.6 percentage points above; the measured number falls inside the stated range.
By their numbers in this assay, from the lowest: compounds 2, 4, 1 and 3 (each within the scatter of the next).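

Fluoro, a single heavy atom against the two of methoxy, now joins methoxy and methyl as a third group tried on this aromatic carbon, and in this assay the exchanges give a number 4 percentage points lower from compound 3 to compound 4 (within the scatter) and a number 3.2 percentage points higher from compound 2 to compound 4 (within the scatter). Replacing the 2-methylphenyl group with 4-fluorophenyl likewise gives a number 2 percentage points lower from compound 1 to compound 4 (within the scatter), so the four compounds cannot be told apart on this read-out, and the change from 4-methoxyphenyl to 4-fluorophenyl adds a further case in which this position shows no firm effect at the one concentration tested. Nothing available here accounts for these numbers or for the absence of a clear step.

Going by these compounds, whether an amine, a carboxylic acid or a longer chain on this aromatic carbon would move the number beyond the usual scatter remains open. All four compounds also share the same core, so what a change elsewhere in that core would do remains just as uncertain, and a single concentration gives no measure of potency for any of them.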